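This account rests on a few compounds, and the source may have more. Where it says the series, first, only, none or still open, it means among the compounds named here.

Measured so far in a functional assay on C6 cells (Rattus norvegicus) for cytotoxicity, read by MTT assay, with a stated time of 24 h, tested at 25 ug/mL; on this read-out higher numbers stand for a weaker effect at the one concentration tested and lower numbers for a stronger effect:
compound 1 `O=C(CSc1ncccn1)N/N=c1/scc(-c2ccc(Br)cc2)n1-c1ccccc1` — 72.3%
compound 2 `Cc1ccc(-c2cs/c(=N/NC(=O)CSc3ncccn3)n2-c2ccccc2)cc1` — 82.7%

For the measured compounds named here, compound 1 stands lowest of the two numbers in this assay; the only measured step is a number 10.4 percentage points higher from compound 1 to compound 2 (beyond the scatter), a change on an aromatic carbon. The next step leads to compound 3 `O=C(CSc1nnnn1-c1ccccc1)N/N=c1/scc(-c2ccc(Br)cc2)n1-c1ccccc1`: 1-phenyl-1H-tetrazol-5-yl in place of pyrimidin-2-yl on a sulfur. That measured step touches a different place than the sulfur, so nothing measured bears directly on this change, and the series shows no exchange at the sulfur at all. The expected step is therefore a number 0.3 percentage points lower from compound 1 to compound 3 (within the scatter), none beyond the scatter, with wide uncertainty. Compound 3 is estimated at 72%, between 58% and 86%.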

Compound 3, a percentage reported as activity, at one concentration (the size of the read-out at that concentration, not a potency): 47.9%
Compound 3: the middle estimate sits 24.1 percentage points above what was measured; measured number below the stated range.
By their numbers in this assay, from the lowest: compound 3; then compound 1; then compound 2.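

For the compounds shown here, the sulfur is the first place where an exchange moves this assay towards a stronger effect at the one concentration tested: 1-phenyl-1H-tetrazol-5-yl in place of pyrimidin-2-yl gives a number 24.4 percentage points lower from compound 1 to compound 3 (beyond the scatter). The position therefore accepts the larger entering group, with its two aromatic rings, without loss of effect. No available evidence accounts for this step.

From the compounds shown here alone, it remains open whether the five-membered aromatic ring or its phenyl carries the step, and how a simple amine or a short alkyl chain on the sulfur would read.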